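Working notes: cytotoxicity of a three-compound amide series

The source may hold more compounds than are shown below. What is called first, only, known or untested is meant among the compounds shown, and "the series" means these compounds.

Three compounds of a shared core have so far been run in an ADME assay on PC-3 cells (Homo sapiens) for cytotoxicity, read by WST assay, tested at 100 uM; on this read-out higher numbers stand for more inhibition at the one concentration tested (going by the name of the read-out) and lower numbers for less inhibition. Compound 1 `Cc1nc(-c2cccc(C(=O)N3CCCC(C(=O)Nc4ccc(Cl)cc4)C3)c2)no1` gives 0%. Compound 2 `CC(C)(C)CC(=O)Nc1cccc(C(=O)N2CCCC(C(=O)Nc3ccc(Cl)cc3)C2)c1` gives 0% in this assay, and compound 3 `N#Cc1cccc(C(=O)N2CCCC(C(=O)Nc3ccc(Cl)cc3)C2)c1` gives 0%. The three single-point exchanges among them move nothing: no change at the digits printed from compound 1 to compound 2 (within the scatter), no change at the digits printed from compound 1 to compound 3 (within the scatter) and no change at the digits printed from compound 2 to compound 3 (within the scatter). Compound 3 therefore stands level with compound 1 and compound 2 at the digits shown, all three at the floor of the read-out.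

Compound 4 `Cc1nc(-c2cccc(C(=O)N3CCCC(C(=O)Nc4ccc(Cl)cc4)C3)c2)cs1` is the next member and is not yet measured. It differs from compound 3 in one place: 2-methyl-1,3-thiazol-4-yl in place of cyano on an aromatic carbon. For the measured compounds named here, the steps that bear on this are the three measured ones, since each of them also exchanges the group on that same aromatic carbon of the core; all three were within the scatter, and none of the groups tried so far, including the five-membered aromatic ring carried by compound 1, lifted the read-out off the floor. On this basis the expected step of no change at the digits printed from compound 3 to compound 4 (within the scatter) is none beyond the scatter. Compound 4 is estimated at 0% in this assay, with a range from -8% to 10%.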

Compound 4, a percentage reported as inhibition, at one concentration (the size of the read-out at that concentration, not a potency): 1%
Estimate against measurement, compound 4: 1 percentage points below; the measured number falls inside the stated range.
By their numbers in this assay, from the lowest: compounds 1, 2, 3 and 4 (each within the scatter of the next).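

The exchange of cyano for 2-methyl-1,3-thiazol-4-yl on this aromatic carbon, meta to a large group, gives a number 1 percentage points higher from compound 3 to compound 4 (within the scatter), while the same group gives a number 1 percentage points higher from compound 2 to compound 4 (within the scatter) in place of (neopentylcarbonyl)amino and a number 1 percentage points higher from compound 1 to compound 4 (within the scatter) in place of 5-methyl-1,2,4-oxadiazol-3-yl. This adds a sulfur-bearing five-membered aromatic ring to the groups tried at this position, and it shows that in this assay an exchange of one five-membered aromatic ring for another, like the exchange of the 2-heavy-atom cyano for the 6-heavy-atom ring, stays within the scatter. No measurement at hand accounts for this flat read-out.

As far as these compounds go, whether an aminomethyl group or a carboxylic acid on this aromatic carbon would give a read-out beyond the scatter remains open. From the compounds shown here alone, all four compounds differ only at this one carbon, so it also remains open whether exchanges elsewhere on the shared core, such as a longer chain in place of the chloro group, would leave the read-out equally flat.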